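The compounds below may be only part of what the source reports. "The series", "measured", "known", "first", "only" and "open" are said of these compounds alone.

Measured compounds:

Compound 1 `Cc1noc(C)c1S(=O)(=O)N1CCC(N2CCC(C)CC2)CC1`: in an ADME assay on HCT-116 cells (Homo sapiens) for cytotoxicity, read by CellTiter-Glo, with a stated time of 72 h (a lower number here means a stronger inhibitor, a higher number a weaker inhibitor), compound 1 gives > 10000 nM, which is a limit of the assay and not a number.
Compound 2 `COc1ccccc1-c1ccc(S(=O)(=O)N2CCC(N3CCC(C)CC3)CC2)cc1`: in this assay compound 2 gives > 5000 nM, again a limit of the assay.
Compound 3 `CC(=O)Nc1ccc(S(=O)(=O)N2CCC(N3CCC(C)CC3)CC2)c2ccccc12`: in this assay compound 3 gives > 10000 nM, also a limit of the assay.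

Compound 1 therefore stands at the limit of > 10000 nM in this assay, at which 2 of the 3 values shown sit, and none of the three compounds has a real number; the remaining value sits at the limit of > 5000 nM in this assay, at which 1 of the 3 values shown sits. The shared core, a sulfonyl linked to a nitrogen in a ring, carries a different group on the sulfonyl sulfur in each compound, and in all three cases the assay reported only a limit.

Compound 4 `COc1cccc(S(=O)(=O)N2CCC(N3CCC(C)CC3)CC2)c1` is the next step from compound 1: 3-methoxyphenyl in place of 3,5-dimethyl-1,2-oxazol-4-yl on a sulfonyl sulfur. Among the measured compounds shown here, with no measured step among the three compounds, and every value being a limit, no move beyond the usual scatter is expected from this change. The step expected from compound 1 to compound 4 in this assay is a step that the limit leaves unreadable from compound 1 to compound 4, that is, essentially no change. Compound 4 is estimated at 15000 nM, with a likely range from 5000 nM to 50000 nM, and most probably the assay will again report only a limit.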

Compound 4, half-maximal inhibitory concentration: > 5000 nM
Compound 4 was reported as a limit; the forecaster's own chance of this, stated with the estimate: 85%; the middle value lies beyond the limit too.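

In this assay compound 1 and compound 4 are both reported only as limits and not as numbers, so no step can be read between them. The compounds shown leave open whether any group on the sulfonyl sulfur would give a real number in this assay.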